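A Second Nitro Group in Place of Methoxy

The source may report more compounds than this note shows. Statements on the series, on what has been measured and on what is new or still open speak of the compounds shown alone.

In a functional assay on HL-60 cells (Homo sapiens) for inhibition (a lower number here means a stronger inhibitor, a higher number a weaker inhibitor), compound 1 `COc1cc(/C=C/c2ccc3ccccc3c2)cc([N+](=O)[O-])c1OC` gives > 10000 nM, which is a limit and not a number. This places compound 1 at the limit of > 10000 nM in this assay, at which 1 of the 2 values shown sits. Compound 2 `COc1cc(/C=C/c2ccc3ccccc3c2)cc(NC(C)=O)c1OC`, which carries acetamido in place of the nitro group, reads 2880 nM. That single measured step, an at least 3.4-fold lower number from compound 1 to compound 2 (0.54 log units; beyond the scatter), lies beyond the scatter, and it is the only one that bears on this series. Compound 3 `COc1c([N+](=O)[O-])cc(/C=C/c2ccc3ccccc3c2)cc1[N+](=O)[O-]` keeps the nitro group of compound 1 and takes nitro in place of methoxy on an aromatic carbon, ortho to a methoxy group and meta to a nitro group: nitro in place of methoxy on an aromatic carbon. Among the compounds with values here, no measured step touches this place, so the evidence is indirect. Only compound 2 2880 nM, which has no nitro group, gives a number, so compound 3 is expected to stay weak. The estimated step is a step that the limit leaves unreadable from compound 1 to compound 3, with no clear gain expected. In this assay the estimate for compound 3 is 15000 nM, with an expected range of 5000 nM to 40000 nM.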

Compound 3, half-maximal inhibitory concentration: > 5000 nM
Compound 3 was reported as a limit; the forecaster's own chance of this, stated with the estimate: 70%; the middle value lies beyond the limit too.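

In this assay compound 3 gives > 5000 nM, which is a limit and not a number. Within the data shown here, compound 1 also stands only as a limit, so no step between compound 1 and compound 3 can be read. The compounds shown leave open whether nitro in place of methoxy changes the value at all.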